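Mirror Image of Compound 3 Expected to Weaken Activity

This account rests on a few compounds, and the source may have more. Where it says the series, first, only, none or still open, it means among the compounds named here.

Measured so far, in a functional assay on HEK293 cells for agonist activity at Neuronal acetylcholine receptor; alpha3/beta4 (Homo sapiens), read by FLIPR; on this read-out lower numbers stand for an effect already at smaller amounts and higher numbers for an effect only at larger amounts of compound:
Compound 1 `Brc1cncc(N2CC[C@H]3CN[C@H]3C2)c1` gives 76 nM.
Compound 2 `Brc1cncc(N2CC[C@@H]3CN[C@@H]3C2)c1` gives 950 nM.
Compound 3 `Brc1cc(N2CC[C@H]3CN[C@H]3C2)cnc1Br` gives 8.2 nM.

Compound 3 stands lowest of the three numbers, with compound 1 the nearest and compound 2 the furthest. Compound 4 `Brc1cc(N2CC[C@@H]3CN[C@@H]3C2)cnc1Br` is its mirror image: the two compounds have the same atoms and bonds and differ only in configuration as drawn: 2 of 2 stereo elements differ (all stereocentres are inverted: mirror images); a stereocentre at a saturated ring carbon is drawn S in compound 3 and R in compound 4; a stereocentre at a saturated ring carbon is drawn R in compound 3 and S in compound 4. For the measured compounds named here, one measured step bears directly on this change, the same inversion from compound 1 to compound 2, which gave a 13-fold higher number from compound 1 to compound 2 (1.10 log units; beyond the scatter) because of the fact that compounds 1 and 2 differ only in the configuration as drawn. The bromo step a 9.3-fold lower number from compound 1 to compound 3 (0.97 log units; beyond the scatter) does not concern configuration. A loss of similar size is therefore expected in this assay, namely a 13-fold higher number from compound 3 to compound 4 (1.11 log units; beyond the scatter). Compound 4 is estimated at 105 nM, with a range from 30 nM to 400 nM.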

Compound 4, half-maximal effective concentration: 110 nM
The estimate for compound 4 lay 1.0-fold (0.02 log units) below the measured number; the measured number falls inside the stated range.
By their numbers in this assay, from the lowest: compound 3; then compounds 1 and 4 (each within the scatter of the next); then compound 2.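

Inverting both stereocentres costs a similar amount with the added bromo present (a 13-fold higher number from compound 3 to compound 4 (1.13 log units; beyond the scatter)), so the earlier loss was not confined to the core of compound 1. Bromo in place of hydrogen also lowers the number on the other mirror-image form (an 8.6-fold lower number from compound 2 to compound 4 (0.94 log units; beyond the scatter)). The two changes therefore look independent across these four compounds, and the size of the bromo step holds steady: the same change on two cores in this assay, a 9.3-fold lower number (0.97 log units; beyond the scatter) from compound 1 to compound 3 and an 8.6-fold lower number (0.94 log units; beyond the scatter) from compound 2 to compound 4, 1.1-fold (0.03 log units) apart, within the scatter of two such steps.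

Going by these compounds, whether chloro, a methyl group or an amine in place of the added bromo would give a similar step on both mirror-image forms stays open. Why one mirror-image form gives the lower numbers also stays open.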